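A few compounds are considered here, and "the series" means these few. Any claim that something is new, unique, unknown or untested is made for them only; others in the source may bear on it.

Measured in a functional assay on HCT-116 cells (Homo sapiens) for cytotoxicity, read by resazurin assay, with a stated time of 48 h; a higher number here means that more compound is needed for the effect, a lower number that less compound is needed:
- compound 1 `O=C(Nc1ccc(Sc2nc3ccccc3s2)c(Cl)c1)c1cccc(Br)c1O`: 12000 nM
- compound 2 `COc1c(Br)cccc1C(=O)Nc1ccc(Sc2nc3ccccc3s2)cc1`: 31000 nM
- compound 3 `O=C(Nc1ccc(Sc2nc3ccccc3s2)cc1)c1cccc(Br)c1O`: 8900 nM

Of these three, compound 2, at 31000 nM, has the highest number, so it needs the most compound for the effect. Compound 4 `COc1c(Br)cccc1C(=O)Nc1ccc(Sc2nc3ccccc3s2)c(Cl)c1` has not yet been measured. It differs from compound 2 by one change: chloro in place of hydrogen on an aromatic carbon.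

The closest evidence is a 1.3-fold lower number from compound 1 to compound 3 (0.13 log units; within the scatter). This is the same change run in reverse, and it lies within the scatter. The other step, a 3.5-fold lower number from compound 2 to compound 3 (0.54 log units; beyond the scatter), is hydrogen in place of methyl on an oxygen on an aromatic ring. Compound 2 and compound 4 both keep that methyl, so this step says little about the chloro. A single pair is thin evidence, and the chloro may not behave the same way when the methyl is present. No change beyond the scatter is therefore expected in this assay.

The expected result is a 1.3-fold higher number from compound 2 to compound 4 (0.11 log units; within the scatter). Compound 4 is estimated at 40000 nM, with an expected range of 20000 nM to 80000 nM.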

Compound 4, half-maximal effective concentration: 8500 nM
Compound 4: middle estimate off by 4.7-fold (0.67 log units), on the high side, and the stated range ends above it.
By their numbers in this assay, from the lowest: compounds 4, 3 and 1 (each within the scatter of the next); then compound 2.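

In this assay, the chloro on the aromatic carbon does matter once the methyl on the oxygen is present, giving a 3.6-fold lower number from compound 2 to compound 4 (0.56 log units; beyond the scatter). The earlier pair without that methyl did not show this, so the effect of the chloro depends on the group elsewhere in the molecule: the same change on two cores in this assay, a 1.3-fold lower number (0.13 log units; within the scatter) from compound 1 to compound 3 and a 3.6-fold higher number (0.56 log units; beyond the scatter) from compound 4 to compound 2, 4.9-fold (0.69 log units) apart, beyond the scatter of two such steps. The methyl step also depends on its partner, since with the chloro present it gives only a 1.4-fold lower number from compound 1 to compound 4 (0.15 log units; within the scatter), and the two changes therefore do not simply add: the same change on two cores in this assay, a 3.5-fold lower number (0.54 log units; beyond the scatter) from compound 2 to compound 3 and a 1.4-fold higher number (0.15 log units; within the scatter) from compound 4 to compound 1, 4.9-fold (0.69 log units) apart, beyond the scatter of two such steps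

These four compounds carry only hydrogen or chloro at this position and only hydrogen or methyl on the oxygen. As far as these compounds go, how a fluoro or an amine at this position, or a longer chain on the oxygen, would behave remains open.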